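Methyl Added to the Fused Ring of Compound 3

The compounds below may be only part of what the source reports. "The series", "measured", "known", "first", "only" and "open" are said of these compounds alone.

Compound 1 `COc1ccc(-c2c(C(=O)c3cc(OC)c(OC)c(OC)c3)sc3ccccc23)cc1` gives 1700 nM in a functional assay on K562 cells (Homo sapiens) for antiproliferative activity, read by MTT assay, with a stated time of 72 h; on this read-out lower numbers stand for stronger inhibition and higher numbers for weaker inhibition. Compound 2 `COc1ccc(-c2c(C(=O)c3cc(OC)c(OC)c(OC)c3)sc3ccccc23)cc1C` reaches only a limit of this assay, > 10000 nM. The change methyl in place of hydrogen on an aromatic carbon therefore produced an at least 5.8-fold higher number from compound 1 to compound 2 (0.76 log units; beyond the scatter). Compound 3 `COc1cc(C(=O)c2sc3ccccc3c2Nc2ccc(C)cc2)cc(OC)c1OC` gives 1600 nM in this assay; its core differs from that of compound 1 by (4-methylphenyl)amino in place of 4-methoxyphenyl on an aromatic carbon, a step of a 1.1-fold lower number from compound 1 to compound 3 (0.03 log units; within the scatter). Compound 4 `COc1cc(C(=O)c2sc3cc(C)ccc3c2Nc2ccc(C)cc2)cc(OC)c1OC` is not yet measured. It carries methyl in place of hydrogen on an aromatic carbon, the same kind of change as from compound 1 to compound 2, but at a different place: here the methyl enters a ring that is part of a fused or bridged system of two rings, meta to a fused ring and para to a fused ring, whereas in compound 2 it entered ortho to a methoxy group and meta to a large group. Resting on the earlier step of an at least 5.8-fold higher number from compound 1 to compound 2 (0.76 log units; beyond the scatter), compound 4 is expected to show a 2.5-fold higher number from compound 3 to compound 4 (0.40 log units; beyond the scatter), an estimated 4000 nM within 1500 nM to 12000 nM.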

Compound 4, half-maximal inhibitory concentration: 1400 nM
Compound 4: the middle estimate sits 2.9-fold (0.46 log units) above what was measured; measured number outside the range, below it.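

In this assay, methyl in place of hydrogen on an aromatic carbon gave a 1.1-fold lower number from compound 3 to compound 4 (0.06 log units; within the scatter), so on this core the added methyl made no difference that can be told from the scatter. The change therefore did not carry over from the core of compound 1 to the core of compound 3, and the two steps differ: the same change on two cores in this assay, an at least 5.8-fold higher number (0.76 log units; beyond the scatter) from compound 1 to compound 2 and a 1.1-fold lower number (0.06 log units; within the scatter) from compound 3 to compound 4, at least 6.7-fold (0.82 log units) apart, beyond the scatter of two such steps. This does not show whether the core or the place of the methyl sets that gap, nor the full size of the earlier step, which ends in the limit of compound 2: the limit of > 10000 nM in this assay, at which 1 of the 4 values shown sits.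

The compounds shown leave open how a methyl at the place it holds in compound 4 would act on the core of compound 1. They also leave open whether an ethyl group or a carboxylic acid at that place would match the methyl.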